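Fluoro for methoxy: expected step in cytotoxicity

This account rests on a few compounds, and the source may have more. Where it says the series, first, only, none or still open, it means among the compounds named here.

Two compounds have numbers in a functional assay on HepG2 cells (Homo sapiens) for cytotoxicity, read by MTT assay, with a stated time of 72 h (a lower number here means a stronger inhibitor, a higher number a weaker inhibitor), so far. Compound 1 `Cc1cc(C)c2c(CSC(=S)N(C)C)cc(=O)oc2c1` gives 62800 nM, and compound 2 `COc1ccc2c(CSC(=S)N3CCCC3)cc(=O)oc2c1` gives 61500 nM. Compound 2 has the lower of the two numbers, but its gap to compound 1 is within the scatter, so neither can be called more active than the other. Compound 3 `O=c1cc(CSC(=S)N2CCCC2)c2ccc(F)cc2o1` carries fluoro in place of methoxy on an aromatic carbon. Within the data shown here, no measured pair shows this change, so no step size is known from data. Since the two measured numbers sit close together despite different substitution, the change is expected to move this assay little, with a 1.0-fold lower number from compound 2 to compound 3 (0.01 log units; within the scatter) amounting to no step beyond the scatter. Compound 3 is expected to give 60000 nM, in the range 25000 nM to 150000 nM.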

Compound 3, half-maximal inhibitory concentration: 62500 nM
The estimate for compound 3 lay 1.0-fold (0.02 log units) below the measured number; the range from low to high includes it.
By their numbers in this assay, from the lowest: compounds 2, 3 and 1 (each within the scatter of the next).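

In this assay, fluoro in place of methoxy on this aromatic carbon gives a 1.0-fold higher number from compound 2 to compound 3 (0.01 log units; within the scatter) as the first step read from a pair differing in one place. Exchanging the methoxy, with its hydrogen-bond acceptor, for fluoro therefore produces no step beyond the scatter at this position. No measurement available here speaks to the reason for this result.

As far as these compounds go, whether an amine or a carboxylic acid on this carbon would give a step beyond the scatter remains open. One pair also leaves open whether the fluoro-for-methoxy step would stay the same with another group on the shared core.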